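The compounds below may be only part of what the source reports. "The series", "measured", "known", "first", "only" and "open" are said of these compounds alone.

Working notes on the series. Growth inhibition is read in a functional assay on AGS cells (Homo sapiens) for antiproliferative activity, read by MTT assay, with a stated time of 48 h; on this read-out higher numbers stand for weaker inhibition of growth and lower numbers for stronger inhibition of growth. Compound 1 `COc1ccc(N(C)c2ncnc3[nH]cnc23)cc1` gives in this assay a value that is a limit of the assay, > 100000 nM. Compound 2 `COc1ccc(N(C)c2nc(Cl)nc3[nH]cnc23)cc1` carries the change chloro in place of hydrogen on an aromatic carbon and in this assay gives 30000 nM. The resulting step is an at least 3.3-fold lower number from compound 1 to compound 2 (0.52 log units; beyond the scatter), read against a limit on its starting side.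

Compound 3 `COc1cc(Cn2cnc3c(Cl)ncnc32)cc(OC)c1` sits on another core; how its core differs from that of compound 1 is not broken down here. In this assay compound 3 gives a limit only, > 100000 nM.

Compound 4 `COc1cc(Cn2cnc3c(Cl)nc(Cl)nc32)cc(OC)c1`, not yet measured, differs from compound 3 by chloro in place of hydrogen on an aromatic carbon. Going by the values given here, this is the same kind of change as the one from compound 1 to compound 2, though the surroundings are not identical: in compound 4 the entering chloro stands meta to a chloro group (1 heavy atom), whereas in compound 2 it stands meta to a large group. The relevant reference point is the limit of > 100000 nM in this assay, at which 2 of the 3 values shown sit, so the starting value of compound 3 is itself only a limit.

For compound 4 the step is expected to be an at least 1.6-fold lower number from compound 3 to compound 4 (0.22 log units; that floor lies within the scatter), resting on the earlier at least 3.3-fold lower number from compound 1 to compound 2 (0.52 log units; beyond the scatter). Compound 4 is estimated at 60000 nM, between 20000 nM and 200000 nM, with a real chance that only a limit is returned.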

Compound 4, concentration for 50% growth inhibition: 3800 nM
Compound 4: the middle estimate sits 16-fold (1.20 log units) above what was measured; measured number outside the range, below it.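

In this assay the change of chloro in place of hydrogen on an aromatic carbon, here between two ring nitrogen atoms, gives an at least 26-fold lower number from compound 3 to compound 4 (1.42 log units; beyond the scatter). The direction of the step therefore carries over from the core of compound 1 to the core of compound 3, and the two steps can be set side by side: the same change on two cores in this assay, an at least 3.3-fold lower number (0.52 log units; beyond the scatter) from compound 1 to compound 2 and an at least 26-fold lower number (1.42 log units; beyond the scatter) from compound 3 to compound 4; the limit leaves it open whether they differ This does not show that the size of the step carries over or that one core responds more strongly than the other, as compound 1 and compound 3 both stand at a limit of the assay and neither step has a fixed starting value: the limit of > 100000 nM in this assay, at which 2 of the 4 values shown sit.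

The compounds shown leave open whether an amine, a methoxy group or a longer chain at that carbon would give a number like that of compound 4. They also leave open whether the direction of the step would hold on a third core.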